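The source may report more compounds than this note shows. Statements on the series, on what has been measured and on what is new or still open speak of the compounds shown alone.

Measured in a functional assay on MCF7 cells (Homo sapiens) for inhibition, read by XTT assay, with a stated time of 48 h; a higher number here means a weaker inhibitor, a lower number a stronger inhibitor:
compound 1 `COc1ccc(C(=O)/C(=C/c2ccccc2Cl)COC(=O)c2ccccc2)cc1` gives 9000 nM
compound 2 `C=C(C(=O)c1ccc(OC)cc1)C(OC(C)=O)C1CCCCC1` gives 14000 nM
compound 3 `C=C(C(=O)c1ccc(OC)cc1)C(OC(=O)c1ccccc1)C1CCCCC1` gives 34300 nM

Compound 3 stands highest of the three numbers in this assay; compound 2 sits nearest, compound 1 furthest. For the measured compounds named here, the only single-place step measured, a 2.5-fold higher number from compound 2 to compound 3 (0.39 log units; beyond the scatter), concerns the ester end and not the carbon changed next. Compound 4 `C=C(C(=O)c1ccc(OC)cc1)C(OC(=O)c1ccccc1)c1ccccc1Cl` differs from compound 3 by 2-chlorophenyl in place of cyclohexyl on a saturated chain carbon bound to a double-bonded chain carbon and an oxygen next to a carbonyl group. Going by the values given here, no measured step covers this exchange. Compound 1 also carries a 2-chlorophenyl, though within a differently built chain, and shows a lower number than compound 3 in this assay, but its two differences from compound 3 cannot be separated. The expectation for compound 4 is therefore a step of uncertain direction, a 1.9-fold lower number from compound 3 to compound 4 (0.28 log units; within the scatter), with wide bounds. Compound 4 is estimated at 18000 nM, within 5000 nM to 60000 nM.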

Compound 4, half-maximal inhibitory concentration: 36000 nM
The estimate for compound 4 lay 2.0-fold (0.30 log units) below the measured number; the measured number falls inside the stated range.
By their numbers in this assay, from the lowest: compounds 1 and 2 (each within the scatter of the next); then compounds 3 and 4 (each within the scatter of the next).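

At the saturated chain carbon bound to a double-bonded chain carbon and an oxygen next to a carbonyl group, 2-chlorophenyl in place of cyclohexyl gives a 1.0-fold higher number from compound 3 to compound 4 (0.02 log units; within the scatter) in this assay. With the ester end held fixed, a six-membered aromatic ring and a six-membered non-aromatic ring read alike at this position. No supporting data explain this equivalence.

From the compounds shown here alone, whether an amine or a carboxylic acid on this carbon would read differently remains open. Also open, going by these compounds, is whether phenyl in place of methyl on the carbonyl carbon would give the same step with 2-chlorophenyl present.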